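Swapping halogens on the allyl-bearing core

The compounds below may be only part of what the source reports. "The series", "measured", "known", "first", "only" and "open" are said of these compounds alone.

Measured so far:
compound 1 `COc1ccccc1/C=c1\c(=O)[nH]/c(=C/c2cccc(Cl)c2Cl)c(=O)n1C`: 200 nM
compound 2 `C=CCn1c(=O)/c(=C\c2ccc(F)c(Br)c2)[nH]c(=O)/c1=C\c1ccccc1OC`: "not active" (no number reported)
compound 3 `COc1ccccc1/C=c1/[nH]c(=O)/c(=C\c2nc[nH]c2C(C)(C)C)[nH]c1=O`: 100 nM

Compound 1 and compound 3 both give clear numbers in a functional assay on MCF7 cells (Homo sapiens) for cytotoxicity, read by CCK-8 assay, with a stated time of 72 h (a lower number here means a stronger inhibitor, a higher number a weaker inhibitor), whereas compound 2 is reported only as inactive, with no number attached. Compound 2 therefore stands apart from the other two, with no place on the numerical scale. Compound 4 `C=CCn1c(=O)/c(=C\c2ccc(Cl)c(Cl)c2)[nH]c(=O)/c1=C\c1ccccc1OC` is the untested partner of compound 2, differing in one spot: 3,4-dichlorophenyl in place of 3-bromo-4-fluorophenyl on a double-bonded chain carbon bound to an aromatic carbon. Both groups carry the same count of heavy atoms and no donors or acceptors, so the change is modest. Since compound 2 gave no number, the step to compound 4 cannot be sized from the shown data. Compound 4 is expected to remain weak, with an estimate of 6000 nM and a range from 800 nM to 40000 nM.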

Compound 4, half-maximal inhibitory concentration: "not active" (no number reported)
Compound 4 has no reported number here, so the estimate cannot be set against anything.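

Compound 2 and compound 4 are both reported without a number in this assay, so no step between them can be read, and no supporting data explain this result. On these data alone, whether any halogen swap on this allyl-bearing core can change potency stays open.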